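This account rests on a few compounds, and the source may have more. Where it says the series, first, only, none or still open, it means among the compounds named here.

Compound 1 `COc1ccccc1Nc1nc(-c2cccc(F)c2)nc2ccc(F)cc12`: > 50000 nM
Compound 2 `Fc1cccc(Nc2nc(-c3cccc(F)c3)nc3ccc(F)cc23)c1`: > 50000 nM
Compound 3 `Fc1cccc(-c2nc(Nc3ccc(Br)cc3)c3cc(F)ccc3n2)c1`: > 50000 nM

All three entries are limits, not numbers, in a functional assay on COLO 205 cells (Homo sapiens) for cytotoxicity, read by MTT assay, with a stated time of 48 h; on this read-out lower numbers stand for stronger inhibition and higher numbers for weaker inhibition: the limit of > 50000 nM in this assay, at which 3 of the 3 values shown sit. Compound 2 therefore has only a limit and no exact position in the series. Compound 4 `Fc1cccc(-c2nc(Nc3ccccc3Br)c3cc(F)ccc3n2)c1` carries 2-bromophenyl in place of 3-fluorophenyl on a nitrogen on an aromatic ring.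

The closest measured change is a step that the two limits leave unreadable from compound 2 to compound 3, which brings in 4-bromophenyl at the same place. Also relevant is a step that the two limits leave unreadable from compound 1 to compound 2. Neither gives a size, so no direction can be drawn from them, and no shift beyond the scatter is expected in this assay. The expected change is a number no higher from compound 2 to compound 4 (the limit leaves the size open). For compound 4 the estimate is 50000 nM, with an expected range of 10000 nM to 80000 nM.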

Compound 4, half-maximal inhibitory concentration: > 50000 nM
Compound 4 was reported as a limit (the forecaster's own chance of this, stated with the estimate: 70%); the middle value sits exactly at the limit.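

Compound 4 is also a limit, so no step to it from compound 1, compound 2 or compound 3 can be read in this assay: the limit of > 50000 nM in this assay, at which 4 of the 4 values shown sit.

The compounds shown leave open how far each lies past that limit, and whether exchanging these groups on the nitrogen shifts the read-out at all.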